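This account rests on a few compounds, and the source may have more. Where it says the series, first, only, none or still open, it means among the compounds named here.

Compound 2 `OCC(CO)OCn1cnc2c(Cl)c(Cl)ccc21` shares its core with compound 1 `CN(C)c1nc2c(Cl)c(Cl)ccc2n1COC(CO)CO`. In a functional assay on KB cells (Homo sapiens) for inhibition (on this read-out lower numbers stand for stronger inhibition and higher numbers for weaker inhibition), compound 2 gives > 100000 nM, which is a limit of the assay rather than a number. In this assay compound 1 likewise gives > 100000 nM, again a limit. The step that the two limits leave unreadable from compound 1 to compound 2 therefore offers no guide to size, and what the two values show is the limit of > 100000 nM in this assay, at which 2 of the 2 values shown sit. Compound 3 `OCC(CO)OCn1c(S)nc2c(Cl)c(Cl)ccc21` is reached from compound 2 by sulfanyl in place of hydrogen on an aromatic carbon. Among the measured compounds shown here, of the measured steps only the one from compound 1 to compound 2 could bear on this change, and its size cannot be read. Compound 3 is expected to sit near that same limit in this assay, so the step of a number no higher from compound 2 to compound 3 (the limit leaves the size open) is expected to be of no readable size. The estimate for compound 3 is accordingly 100000 nM, within a range from 20000 nM to 500000 nM, with a strong chance that only a limit is reported.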

Compound 3, half-maximal inhibitory concentration: > 100000 nM
Compound 3 gave a limit, no number (the forecaster's own chance of this, stated with the estimate: 80%); the middle value lies on the limit itself.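

No step among compound 1, compound 2 and compound 3 can be read, since all three give only a limit in this assay: the limit of > 100000 nM in this assay, at which 3 of the 3 values shown sit.

The compounds shown leave open whether hydrogen, dimethylamino or sulfanyl on that aromatic carbon makes any difference in this assay.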